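A few compounds are considered here, and "the series" means these few. Any claim that something is new, unique, unknown or untested is made for them only; others in the source may bear on it.

Compound 1, `COC(=O)N(C)CC#CCN1CCCC1`, and compound 2, `COC(=O)N(C)CC#CCn1ccnc1`, share one core, while compound 3, `CC(C#CCN1CCCC1)N1CCN(C)C1=O`, is built on another; the difference between the core of compound 1 and the core of compound 3 is not broken down here. Compound 4, `CC(C#CCn1ccnc1)N1CCN(C)C1=O`, has not yet been measured. All of them belong to a functional assay on the whole organism for antagonist activity, with Mus musculus as the target; a higher number here means that more compound is needed for the effect, a lower number that less compound is needed.

In this assay compound 1 gives only a limit, > 10 mg/kg, and no number. In this assay compound 2 also gives only a limit, > 100 mg/kg. The change from one to the other, (1H-imidazol-1-yl in place of pyrrolidin-1-yl on a saturated chain carbon bound to a triple-bonded carbon), gives a step that the two limits leave unreadable from compound 1 to compound 2: with one value sitting at the limit of > 10 mg/kg in this assay, at which 1 of the 3 values shown sits, and the other at the limit of > 100 mg/kg in this assay, at which 1 of the 3 values shown sits, the size of that step cannot be read. In this assay, for the measured compounds named here, compound 3 gives 25 mg/kg, the only number among the three measured compounds.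

Going by the values given here, compound 4 differs from compound 3 by 1H-imidazol-1-yl in place of pyrrolidin-1-yl on a saturated chain carbon bound to a triple-bonded carbon, the same change as the one between compound 1 and compound 2, at the same place. The measured example of this change left its size unreadable. The expectation for compound 4 therefore rests on compound 3 at 25 mg/kg and on the structural change alone. The step from compound 3 to compound 4 is expected to be a 2.4-fold higher number from compound 3 to compound 4 (0.38 log units; beyond the scatter). Compound 4 is estimated at 60 mg/kg, with a range from 20 mg/kg to 200 mg/kg, and a real chance that only a limit will be reported.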

Compound 4, dose for half-maximal effect: 21 mg/kg
For compound 4 the middle estimate is 2.9-fold (0.46 log units) above the measured one; the range from low to high includes it.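

On the core of compound 3, putting 1H-imidazol-1-yl in place of pyrrolidin-1-yl gives in this assay a step of a 1.2-fold lower number from compound 3 to compound 4 (0.08 log units; within the scatter), so in this one pair the two groups cannot be told apart, even though one ring is aromatic and the other is not. On the core of compound 1, the same change starts from a value that is only a limit of the assay: the limit of > 10 mg/kg in this assay, at which 1 of the 4 values shown sits. Compound 2 also gives only a limit of the assay, so the step on that core cannot be read, and the result therefore does not show whether the change behaves alike on both cores, only that it can be made on the core of compound 3 with no difference beyond the scatter: the limit of > 100 mg/kg in this assay, at which 1 of the 4 values shown sits.

The compounds shown leave open how other groups would read on a saturated chain carbon bound to a triple-bonded carbon, such as a piperidin-1-yl ring or a dimethylamino group. For the compounds shown here, with only one readable pair, they also leave open whether the result on the core of compound 3 is a rule for this series or a single case.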